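Amide nitrogen substituents on a shared core: cytotoxicity notes

This account rests on a few compounds, and the source may have more. Where it says the series, first, only, none or still open, it means among the compounds named here.

Measured compounds:
Compound 1, `C=CC1=C(C(=O)NC(C)(C)C)C(c2ccc(OC)cc2)OC1`, in a functional assay on SW480 cells (Homo sapiens) for cytotoxicity, read by MTT assay, with a stated time of 24 h (on this read-out higher numbers stand for weaker inhibition and lower numbers for stronger inhibition), gives > 100000 nM, which is a limit of the assay and not a number.
Compound 2, `C=CC1=C(C(=O)NC2CCCCC2)C(c2ccc(OC)cc2)OC1`, in this assay gives > 100000 nM, again a limit.
Compound 3, `C=CC1=C(C(=O)NCCC)C(c2ccc(OC)cc2)OC1`, in this assay gives > 100000 nM, also a limit.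

Compound 3 therefore stands at the limit of > 100000 nM in this assay, at which 3 of the 3 values shown sit, with no number of its own. Compound 4, `C=CC1=C(C(=O)NCc2ccc(C)cc2)C(c2ccc(OC)cc2)OC1`, differs from it by 4-methylphenyl in place of ethyl on a saturated chain carbon bound to an amide-type nitrogen. The measured steps among the amide nitrogen substituents are a step that the two limits leave unreadable from compound 1 to compound 2, a step that the two limits leave unreadable from compound 1 to compound 3 and a step that the two limits leave unreadable from compound 2 to compound 3; none of them has a readable size, so they give no direction for a change of this kind. Nothing among the three compounds suggests that a 4-methylbenzyl group would move the read-out past the limit, but nothing rules it out either. The expected step from compound 3 to compound 4 is a step that the limit leaves unreadable from compound 3 to compound 4, with the likeliest outcome again a limit. Compound 4 is estimated at 120000 nM in this assay, with a range from 30000 nM to 400000 nM.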

Compound 4, half-maximal inhibitory concentration: 31700 nM
Beside the measured number, compound 4's estimate is 3.8-fold (0.58 log units) above it, and the stated range covers the measured number.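

In this assay, the amide nitrogen position gives its first readable change: an at least 3.1-fold lower number from compound 3 to compound 4 (0.49 log units; beyond the scatter), alongside an at least 3.1-fold lower number from compound 2 to compound 4 (0.49 log units; beyond the scatter) and an at least 3.1-fold lower number from compound 1 to compound 4 (0.49 log units; beyond the scatter). The steps among compound 1, compound 2 and compound 3 cannot be read, so these three steps carry all the information on this position, and each gives only a minimum size. Of the amide nitrogen substituents shown, only 4-methylbenzyl gives a number, while propyl, cyclohexyl and tert-butyl stay at the limit: the limit of > 100000 nM in this assay, at which 3 of the 4 values shown sit.

The compounds shown do not tell whether the change depends on the aromatic ring alone or also on its 4-methyl group, which a plain benzyl or a 4-chlorobenzyl group would separate. They also do not tell whether a longer link, as in 2-phenylethyl, would take the number further down.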